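The source may report more compounds than this note shows. Statements on the series, on what has been measured and on what is new or still open speak of the compounds shown alone.

Working notes on the series, read in a functional assay on HCT-116 cells (Homo sapiens) for antiproliferative activity; a higher number here means a weaker inhibitor, a lower number a stronger inhibitor. Compound 1 (`COc1ccc(-c2snnc2-c2cc(OC)c(OC)c(OC)c2)cc1O`) gives 3 nM. Compound 2 (`COc1cc(-c2nnsc2-c2ccc(F)cc2)cc(OC)c1OC`) reads > 1000 nM, and this is a limit of the assay, not a number. Only that limit is known for compound 2, so any step starting from it is uncertain in size.

Compound 3 (`COc1ccc(-c2snnc2-c2cc(OC)c(OC)c(OC)c2)cc1`) is the next to be read. Relative to compound 2, methoxy stands in place of fluoro on an aromatic carbon, para to a large group: methoxy in place of fluoro on an aromatic carbon.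

Among the compounds with values here, no measured step isolates this change. The expectation rests on compound 1, which also carries a methoxy on that ring and reaches 3 nM. A large step toward stronger inhibition in this assay, well beyond the scatter, is expected: an at least 50-fold lower number from compound 2 to compound 3 (1.69 log units; beyond the scatter). For compound 3 the estimated value is 20 nM, with an expected range from 3 nM to 200 nM.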

Compound 3, half-maximal inhibitory concentration: 25 nM
The estimate for compound 3 lay 1.3-fold (0.10 log units) below the measured number, within the range that was stated.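

In this assay, methoxy in place of fluoro on an aromatic carbon, para to a large group, gives an at least 40-fold lower number from compound 2 to compound 3 (1.60 log units; beyond the scatter), the only direct read of this change in the series. Compound 2 stands at a limit of the assay, not a number, so this step is a bound and its true size is unknown: the limit of > 1000 nM in this assay, at which 1 of the 3 values shown sits.

Hydrogen in place of hydroxy on an aromatic carbon gives an 8.3-fold higher number from compound 1 to compound 3 (0.92 log units; beyond the scatter), so the hydroxy is not required for a nanomolar value, although its loss is a real, modest step.

The compounds shown leave open whether an amine or a longer chain such as ethoxy at the methoxy position would hold the value of compound 3. They also leave open whether an amine could stand in for the hydroxy of compound 1.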